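From Methyl to Fluoro: One Atom Exchanged, Effect Unknown

The source may report more compounds than this note shows. Statements on the series, on what has been measured and on what is new or still open speak of the compounds shown alone.

Of the compounds shown here, three sharing one core have been tested in a functional assay on A549 cells (Homo sapiens) for inhibition, read by MTT assay, with a stated time of 72 h; on this read-out higher numbers stand for weaker inhibition and lower numbers for stronger inhibition. Compound 1 `O=C1Nc2ccc(F)cc2/C1=N/NC(=S)N1CCN(c2ccccc2)CC1` gives 20700 nM, compound 2 `O=C1Nc2cc(Br)ccc2/C1=N/NC(=S)N1CCN(c2ccccc2)CC1` gives 15800 nM, and compound 3 `Cc1ccccc1N1CCN(C(=S)N/N=C2\C(=O)Nc3ccc(Cl)cc32)CC1` gives 6520 nM, the lowest of the three and so the strongest inhibitor among them, since its gaps to compound 2 and to compound 1 both lie beyond the usual scatter. Compound 4 `O=C1Nc2ccc(Cl)cc2/C1=N/NC(=S)N1CCN(c2ccccc2F)CC1` has not yet been measured. It differs from compound 3 in a single place: fluoro in place of methyl on an aromatic carbon. For the measured compounds named here, no pair of measured compounds shows this exact change, so there is no earlier step to lean on. An exchange of one heavy atom for one heavy atom is expected to move this assay only a little, most likely within the scatter. Compound 4 is therefore expected to give about 8000 nM, between 3500 nM and 18000 nM. The expected step is a 1.2-fold higher number from compound 3 to compound 4 (0.09 log units; within the scatter).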

Compound 4, half-maximal inhibitory concentration: 10500 nM
Estimate against measurement, compound 4: 1.3-fold (0.12 log units) below; measured number inside the range.
By their numbers in this assay, from the lowest: compounds 3, 4, 2 and 1 (each within the scatter of the next, the first and the last beyond it).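

In this assay, for the compounds shown here, the exchange of methyl for fluoro on this aromatic carbon, ortho to a large group, gives a 1.6-fold higher number from compound 3 to compound 4 (0.21 log units; within the scatter) and so provides the first direct reading of this change. At this position, 2-methylphenyl and 2-fluorophenyl cannot be told apart in this assay. Nothing available bears on the reason for this result. As far as these compounds go, whether an amine, a hydroxyl or a methoxy group on the same carbon would clearly shift the number stays open. So does whether this exchange would read the same on a different core.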